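Swapping the chlorophenyl for a pyrimidinyl on the ring nitrogen

The source may report more compounds than this note shows. Statements on the series, on what has been measured and on what is new or still open speak of the compounds shown alone.

Compound 1 `Cc1ccccc1-n1ncc2c(=O)n(-c3ccc(Cl)cc3)c(C)nc21` and compound 2 `Cc1nc2c(cnn2-c2ccc(Cl)cc2)c(=O)n1-c1ccc(Cl)cc1` share one core and differ only in the group carried on an aromatic nitrogen of the five-membered ring. In an in vitro functional assay on cells for antagonist activity at metabotropic glutamate receptor 1 (Homo sapiens), read by FLIPR and calcium flux (on this read-out lower numbers stand for stronger inhibition and higher numbers for weaker inhibition), compound 1 gives 350 nM, while compound 2 gives 1100 nM. Within the data shown here, that step, a 3.1-fold higher number from compound 1 to compound 2 (0.50 log units; beyond the scatter), makes compound 2 the higher of the two numbers measured so far, so it is the weaker inhibitor of this pair.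

Compound 3 `Cc1nc2c(cnn2-c2cncnc2)c(=O)n1-c1ccc(Cl)cc1` has not yet been measured. It arises from compound 2 by pyrimidin-5-yl in place of 4-chlorophenyl on an aromatic nitrogen. Among the measured compounds shown here, only one measured step touches this position, the one from compound 1 to compound 2, and it concerns a different pair of groups, so it shows that the group at this nitrogen can shift the number by a modest amount but does not show the direction for a pyrimidinyl. For the measured compounds named here, with no closer precedent, the expectation for compound 3 is a number somewhat higher than that of compound 2, estimated as a 2.3-fold higher number from compound 2 to compound 3 (0.36 log units; beyond the scatter) in this assay, with wide uncertainty. The estimate for compound 3 is therefore 2500 nM, expected to fall between 700 nM and 9000 nM.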

Compound 3, half-maximal inhibitory concentration: 9800 nM
Estimate against measurement, compound 3: 3.9-fold (0.59 log units) below; measured number above the stated range.
By their numbers in this assay, from the lowest: compound 1; then compound 2; then compound 3.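

On this aromatic nitrogen, the pyrimidin-5-yl group gives the weakest inhibition of the three compounds in this assay, with an 8.9-fold higher number from compound 2 to compound 3 (0.95 log units; beyond the scatter) and a 28-fold higher number from compound 1 to compound 3 (1.45 log units; beyond the scatter). The earlier pair showed that a change here can shift the number, but both of those groups are six-membered aromatic rings of carbon only; this result shows a much wider spread once the ring has 2 hetero atoms and 2 hydrogen-bond acceptors, and no compound shown goes against that contrast. Nothing measured here accounts for the rise.

The step to compound 3 removes the chlorine and brings in the ring nitrogens at the same time, so the compounds shown cannot separate the two changes. A plain phenyl group would isolate the loss of the chlorine, while a pyridin-3-yl group, with a single ring nitrogen, would show whether one such atom is enough to raise the number, and neither group appears among these compounds.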